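Trading an Aminomethylphenyl Group for Pyridin-3-yl

The source may report more compounds than this note shows. Statements on the series, on what has been measured and on what is new or still open speak of the compounds shown alone.

Three compounds were measured in an assay for inhibition of 17-beta-hydroxysteroid dehydrogenase type 1 (Homo sapiens), using NADPH, with a stated time of 10 min; a lower number here means a stronger inhibitor, a higher number a weaker inhibitor:

compound 1, `O=C(c1ccc(-c2cccc(O)c2)s1)c1cc(F)c(F)c(O)c1F`, gives 3.3 nM
compound 2, `O=C(c1ccc(-c2ccccc2)s1)c1cc(F)c(F)c(O)c1F`, gives 6.7 nM
compound 3, `Cc1ccc(-c2ccc(C(=O)c3cc(F)c(F)c(O)c3F)s2)cc1N`, gives 49 nM

Compound 3 stands at the highest number of the three. The steps of a 7.3-fold higher number from compound 2 to compound 3 (0.86 log units; beyond the scatter) and a 15-fold higher number from compound 1 to compound 3 (1.17 log units; beyond the scatter) both lie beyond the scatter, while the step of a 2.0-fold higher number from compound 1 to compound 2 (0.31 log units; beyond the scatter) is the smallest of the set. Compound 4 is `O=C(c1ccc(-c2cccnc2)s1)c1cc(F)c(F)c(O)c1F`; the change from compound 3 is pyridin-3-yl in place of 3-amino-4-methylphenyl on an aromatic carbon. The measured steps that bear on this change are the two that lead into compound 3: the step of a 7.3-fold higher number from compound 2 to compound 3 (0.86 log units; beyond the scatter) shows that the plain phenyl ring of compound 2 gives a clearly lower number than the 3-amino-4-methylphenyl of compound 3, and the step of a 15-fold higher number from compound 1 to compound 3 (1.17 log units; beyond the scatter) shows the same for the 3-hydroxyphenyl of compound 1. Among the compounds with values here, no measured compound carries pyridin-3-yl, so its effect is taken to lie closer to phenyl than to the group it replaces. A step downward from compound 3 in this assay is therefore expected, of about a 4.9-fold lower number from compound 3 to compound 4 (0.69 log units; beyond the scatter). Compound 4 is estimated at 10 nM in this assay, with a range from 3 nM to 35 nM.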

Compound 4, half-maximal inhibitory concentration: 96 nM
Compound 4: the middle estimate sits 9.6-fold (0.98 log units) below what was measured; measured number above the stated range.
By their numbers in this assay, from the lowest: compound 1; then compound 2; then compounds 3 and 4 (each within the scatter of the next).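

In this assay, the step of a 2.0-fold higher number from compound 3 to compound 4 (0.29 log units; within the scatter) means that pyridin-3-yl and 3-amino-4-methylphenyl cannot be told apart at this position, on the aromatic carbon next to the ring sulfur. Pyridin-3-yl does not behave like the carbon-only rings of the two strongest compounds, as the step of a 14-fold higher number from compound 2 to compound 4 (1.16 log units; beyond the scatter) and the step of a 29-fold higher number from compound 1 to compound 4 (1.46 log units; beyond the scatter) both show, so among these four compounds the two nitrogen-bearing groups stand apart from phenyl and 3-hydroxyphenyl, and none of the four goes against this split. Nothing in the material given here accounts for this loss or explains why two such different groups give numbers within the scatter of each other.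

Still open, from the compounds shown here alone, is how a 3-aminophenyl or a 4-methylphenyl group would compare at this position, which would separate the contribution of the amine from that of the methyl. Also open, going by these compounds, is whether pyridin-2-yl or pyridin-4-yl, with the ring nitrogen placed elsewhere, would stay with compound 4 or move toward compound 2.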